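Branching the tail end of a depsipeptide ring

The compounds below may be only part of what the source reports. "The series", "measured", "known", "first", "only" and "open" are said of these compounds alone.

Measured so far:
compound 1 `CC[C@H](C)[C@@H]1NC(=O)[C@@H](CC(C)C)NC(=O)[C@H]([C@@H](C)O)NC(=O)[C@H](CO)NC(=O)[C@@H](CC(C)C)NC(=O)C[C@@H](CCCCCCC(C)C)OC1=O` — 50000 nM
compound 2 `CCCCCC/C=C\CCC[C@@H]1CC(=O)N[C@H](CC(C)C)C(=O)N[C@@H](CO)C(=O)N[C@@H]([C@@H](C)O)C(=O)N[C@H](CC(C)C)C(=O)N[C@@H]([C@@H](C)CC)C(=O)O1` — 28000 nM
compound 3 `CCCCCCCCCCC[C@@H]1CC(=O)N[C@H](CC(C)C)C(=O)N[C@@H](CO)C(=O)N[C@@H]([C@@H](C)O)C(=O)N[C@H](CC(C)C)C(=O)N[C@@H]([C@@H](C)CC)C(=O)O1` — 18000 nM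

All three were tested in a functional assay on HCT-116 cells (Homo sapiens) for cytotoxicity; a lower number here means a stronger inhibitor, a higher number a weaker inhibitor. Compound 3 gives the lowest number of the three, though its gap to compound 2 is within the scatter (a 1.6-fold lower number from compound 2 to compound 3 (0.19 log units; within the scatter)), while its gap to compound 1 is beyond it (a 2.8-fold lower number from compound 1 to compound 3 (0.44 log units; beyond the scatter)). Compound 4 `CC[C@H](C)[C@@H]1NC(=O)[C@@H](CC(C)C)NC(=O)[C@H]([C@@H](C)O)NC(=O)[C@H](CO)NC(=O)[C@@H](CC(C)C)NC(=O)C[C@@H](CCCCCCCCC(C)C)OC1=O` differs from compound 3 by a single rearrangement of the chain: isopropyl in place of propyl on a saturated chain carbon, eight bonds along the chain from a saturated ring carbon. Among the compounds with values here, the step that bears on this is the one from compound 1 to compound 3, where the branched end gave way to a straight one and the number fell modestly (a 2.8-fold lower number from compound 1 to compound 3 (0.44 log units; beyond the scatter)). Restoring a branch, as in compound 4, is therefore expected to push the number back up by a modest amount, roughly a 1.7-fold higher number from compound 3 to compound 4 (0.22 log units; within the scatter). For compound 4 the estimate is 30000 nM, with a range from 13000 nM to 70000 nM.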

Compound 4, half-maximal inhibitory concentration: 17000 nM
The estimate for compound 4 lay 1.8-fold (0.25 log units) above the measured number; the range from low to high includes it.
By their numbers in this assay, from the lowest: compounds 4, 3, 2 and 1 (each within the scatter of the next, the first and the last beyond it).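

In this assay, a branched chain end reads the same as a straight one of equal size: swapping propyl for isopropyl, eight bonds along the chain from a saturated ring carbon, changes nothing beyond the scatter (a 1.1-fold lower number from compound 3 to compound 4 (0.02 log units; within the scatter)). The gap to compound 1 persists with both chains branched (a 2.9-fold lower number from compound 1 to compound 4 (0.47 log units; beyond the scatter)), so here it goes with isopentyl in place of isopropyl, not with the branch itself, while the step involving the unsaturated chain stays within the scatter (a 1.6-fold lower number from compound 2 to compound 4 (0.22 log units; within the scatter)). No supporting data offer an explanation for these results. Going by these compounds, whether an amine or a carboxylic acid at the chain end, or a still longer chain, would move the number remains open.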